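The source may hold more compounds than are shown below. What is called first, only, known or untested is meant among the compounds shown, and "the series" means these compounds.

The series rests on a shared core with a sulfonamide link to an aryl ring that carries a triazole bearing an aryl substituent on one of its nitrogens. In a functional assay on HepG2 cells (Homo sapiens) for antiproliferative activity, read by MTT assay, with a stated time of 24 h (a lower number here means a stronger inhibitor, a higher number a weaker inhibitor), compound 1 `O=c1[nH]cc(S(=O)(=O)Nc2ccccc2-c2cn(-c3ccccc3Cl)nn2)c(=O)[nH]1` gives 2240 nM. Compound 2 `Cc1ccccc1-n1cc(-c2cccc(NS(=O)(=O)c3c[nH]c(=O)[nH]c3=O)c2)nn1` gives 9570 nM in this assay. Compound 3 `Cc1ccc(-n2cc(-c3cccc(NS(=O)(=O)c4c[nH]c(=O)[nH]c4=O)c3)nn2)cc1` reaches only a limit of the assay in this assay, > 20000 nM, so its place on the scale is known only as a bound; this is the limit described as the limit of > 20000 nM in this assay, at which 1 of the 3 values shown sits. Among the compounds with values here, the one measured step that touches compound 3 is an at least 2.0-fold higher number from compound 2 to compound 3 (0.32 log units; beyond the scatter), a 4-methylphenyl in place of a 2-methylphenyl on the aromatic nitrogen. Compound 4 `O=c1[nH]cc(S(=O)(=O)Nc2cccc(-c3cn(-c4ccccc4Cl)nn3)c2)c(=O)[nH]1` reverses that direction: the change is 2-chlorophenyl in place of 4-methylphenyl on an aromatic nitrogen, a 2-chlorophenyl entering where the 4-methylphenyl stood. Since the 2-methylphenyl of compound 2 sat at 9570 nM, a group bearing a 2-substituent again is expected to bring the number back down, and the step from compound 3 to compound 4 is estimated as an at least 2.5-fold lower number from compound 3 to compound 4 (0.39 log units; beyond the scatter). For compound 4 the estimate in this assay is 8000 nM, within 3000 nM to 20000 nM.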

Compound 4, half-maximal inhibitory concentration: 4030 nM
The estimate for compound 4 lay 2.0-fold (0.30 log units) above the measured number; low and high end bracket the measured number.
By their numbers in this assay, from the lowest: compounds 1 and 4 (each within the scatter of the next); then compound 2. At a limit, above all of these: compound 3.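

In this assay, the 2-chlorophenyl on the aromatic nitrogen gives an at least 4.9-fold lower number from compound 3 to compound 4 (0.69 log units; beyond the scatter), which shows that this position tolerates a change of aryl group with a clear gain, where the earlier step at this nitrogen had shown only a loss. Comparing the two groups that carry their substituent at the same place, chloro in place of methyl on an aromatic carbon gives a 2.4-fold lower number from compound 2 to compound 4 (0.38 log units; beyond the scatter), so the identity of that substituent counts here as well as its place on the ring. The size of the first step stays open because compound 3 stands at a limit: the limit of > 20000 nM in this assay, at which 1 of the 4 values shown sits.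

The compounds shown leave open whether a 2-fluorophenyl or a 2-methoxyphenyl on this nitrogen would follow the 2-chlorophenyl. They also leave open how a 4-chlorophenyl there would compare with the 4-methylphenyl of compound 3.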